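Adding a Methyl Group: What Cytotoxicity to Expect

A few compounds are considered here, and "the series" means these few. Any claim that something is new, unique, unknown or untested is made for them only; others in the source may bear on it.

Compound 1 has the structure `CC(=O)Oc1ccc2ccc(=O)oc2c1Cc1c(-c2ccccc2)[nH]c2ccccc12`. In an ADME assay on MT4 cells (Homo sapiens) for cytotoxicity, read by MTT assay, with a stated time of 96 h (on this read-out higher numbers stand for lower toxicity in this test and lower numbers for higher toxicity in this test), compound 1 gives > 100000 nM, which is a limit of the assay and not a number. Compound 2, with the structure `CC(=O)Oc1ccc2c(C)cc(=O)oc2c1Cc1c(-c2ccccc2)[nH]c2ccccc12`, carries one change relative to compound 1, namely (methyl in place of hydrogen on an aromatic carbon). In this assay compound 2 gives > 100000 nM, again a limit of the assay rather than a number. The step that the two limits leave unreadable from compound 1 to compound 2 cannot be read, because of the limit of > 100000 nM in this assay, at which 2 of the 3 values shown sit.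

Compound 3 has the structure `Cc1[nH]c2ccccc2c1Cc1c(OC(=O)CCCC(=O)O)ccc2ccc(=O)oc12`. The difference between the core of compound 3 and the core of compound 1 is not broken down here. In this assay, among the measured compounds shown here, compound 3 gives 27000 nM, the only actual number among the three measured compounds.

Compound 4, with the structure `Cc1[nH]c2ccccc2c1Cc1c(OC(=O)CCCC(=O)O)ccc2c(C)cc(=O)oc12`, is not yet measured. It differs from compound 3 by methyl in place of hydrogen on an aromatic carbon. For the measured compounds named here, this is the same change as the one from compound 1 to compound 2, at the same place.

Going by the values given here, since the only earlier instance of this change sits at a limit and gives no readable size, there is no measured basis for expecting a shift in either direction. Compound 4 is therefore expected to show a step of about a 1.1-fold higher number from compound 3 to compound 4 (0.05 log units; within the scatter), meaning little difference from compound 3. The estimate for compound 4 in this assay is 30000 nM, expected to fall between 10000 nM and 90000 nM.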

Compound 4, half-maximal cytotoxic concentration: 29000 nM
The estimate for compound 4 lay 1.0-fold (0.01 log units) above the measured number, and the stated range covers the measured number.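

In this assay the methyl in place of hydrogen on an aromatic carbon gives a 1.1-fold higher number from compound 3 to compound 4 (0.03 log units; within the scatter), so on the core of compound 3 this change leaves two values that cannot be told apart. The same change on the core of compound 1 offers nothing to set beside this step, because compound 1 and compound 2 both give a limit of the assay and not a number: the limit of > 100000 nM in this assay, at which 2 of the 4 values shown sit. The series therefore holds a single readable instance of the change, which shows that it made no difference beyond the scatter on one core, but it does not show that the result carries over to the core of compound 1 or to any other core, since a transfer needs at least two readable steps to compare.

Going by these compounds, it remains open whether a different group at the same place, such as ethyl, chlorine or an amine, would give a step beyond the scatter in this test. On these data alone, it is also open how the methyl change would read on a further core with measurable values, for example one with an amine in place of the carboxylic acid at the end of the chain.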